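Swapping Chloro for Methoxy on the Fused Ring Core

A few compounds are considered here, and "the series" means these few. Any claim that something is new, unique, unknown or untested is made for them only; others in the source may bear on it.

Compound 1 `CN1CCc2cc(Cl)c(NS(=O)(=O)c3ccc(-c4ccc(Cl)cc4)cc3)cc2CC1` gives 50.1 nM in an assay on isolated protein for displacement of a labelled ligand from 5-hydroxytryptamine receptor 6 (Homo sapiens), read by radioligand binding; a lower number here means a stronger inhibitor, a higher number a weaker inhibitor. Compound 2 `Cc1cc(S(=O)(=O)Nc2ccc3c(c2)CCN(C)CC3)ccc1-c1ccc(Cl)cc1` gives 5.01 nM. Compound 3 `CN1CCc2ccc(NS(=O)(=O)c3ccc(-c4ccc(F)c(Cl)c4)cc3)cc2CC1` gives 7.94 nM.

Among these three, compound 1 stands at the highest number, the weakest binder shown: its number lies beyond the scatter above compound 3 and further still above compound 2. Compound 4 `COc1cc2c(cc1NS(=O)(=O)c1ccc(-c3ccc(Cl)cc3)cc1)CCN(C)CC2` is compound 1 with a single change, methoxy in place of chloro on an aromatic carbon. No measured pair shows this exact swap, so the expectation for this assay rests on the spread of the numbers shown. The change is expected to lower the number by a modest 2.0-fold lower number from compound 1 to compound 4 (0.30 log units; within the scatter). Compound 4 is expected to give about 25 nM, within a range from 8 nM to 80 nM.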

Compound 4, inhibition constant: 10 nM
Estimate against measurement, compound 4: 2.5-fold (0.40 log units) above; low and high end bracket the measured number.
By their numbers in this assay, from the lowest: compounds 2, 3 and 4 (each within the scatter of the next); then compound 1.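

In this assay the swap gives a 5.0-fold lower number from compound 1 to compound 4 (0.70 log units; beyond the scatter) and is the only direct reading of this position among the compounds shown. So this aromatic carbon, ortho to a large group, does respond to what sits on it, and methoxy is tolerated there at least as well as chloro. Nothing available explains the step, which exchanges chloro for methoxy and adds one hydrogen-bond acceptor.

Two groups on one carbon cannot show a trend. Going by these compounds, how a hydroxyl, an amine or the longer ethoxy chain would fare at this carbon remains open.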